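This account rests on a few compounds, and the source may have more. Where it says the series, first, only, none or still open, it means among the compounds named here.

Compound 1 `Nc1cc(-c2cnc3[nH]cc(-c4ccncc4)c3c2)ccc1Cl` gives 53.7 nM in an assay on isolated protein for inhibition of high affinity nerve growth factor receptor (Homo sapiens), read by 33P incorporation; a higher number here means a weaker inhibitor, a lower number a stronger inhibitor.
Compound 2 `Cc1ccc(-c2cnc3[nH]cc(-c4ccncc4)c3c2)cc1N` gives 22.2 nM in this assay.

Among the compounds with values here, compound 2 stands lowest of the two numbers measured so far in this assay; its nearest neighbour is compound 1, and the one known step, a 2.4-fold lower number from compound 1 to compound 2 (0.38 log units; beyond the scatter), is modest but beyond the scatter. Compound 3 `COc1ccc(-c2cnc3[nH]cc(-c4ccncc4)c3c2)cc1N` has not yet been measured. It differs from compound 2 by a single change: methoxy in place of methyl on an aromatic carbon. Within the data shown here, no measured step bears directly on this exchange. Among the measured compounds shown here, the only step in hand, a 2.4-fold lower number from compound 1 to compound 2 (0.38 log units; beyond the scatter), swaps chloro for methyl, which is a different kind of exchange, so neither the size nor the direction of a methyl-to-methoxy change in this assay can be read from these two compounds. On that basis no step beyond the scatter is expected in this assay from compound 2 to compound 3, with a wide range allowed either way. The estimate for compound 3 in this assay is 25 nM, between 8 nM and 80 nM. That would mean an expected step of a 1.1-fold higher number from compound 2 to compound 3 (0.05 log units; within the scatter).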

Compound 3, half-maximal inhibitory concentration: 33.2 nM
Beside the measured number, compound 3's estimate is 1.3-fold (0.12 log units) below it; the range from low to high includes it.
By their numbers in this assay, from the lowest: compounds 2, 3 and 1 (each within the scatter of the next, the first and the last beyond it).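

In this assay, methoxy in place of methyl at this position, ortho to an amino group and para to a large group, gives a 1.5-fold higher number from compound 2 to compound 3 (0.17 log units; within the scatter) and so does not shift the number measurably. Methoxy in place of chloro gives a 1.6-fold lower number from compound 1 to compound 3 (0.21 log units; within the scatter) and is also too small a step to read, even though methyl in place of chloro gives a 2.4-fold lower number from compound 1 to compound 2 (0.38 log units; beyond the scatter) and stands beyond the scatter. The position therefore accepts methoxy, with one more heavy atom than methyl and a hydrogen-bond acceptor that methyl lacks, without a step beyond the scatter to either neighbouring compound, and no measurement at hand offers an explanation for these numbers.

On these data alone, whether a longer chain such as ethoxy or butoxy, or a group such as a hydroxyl or a carboxylic acid, would be accepted here as well remains open. All three compounds also keep the amino group and the shared core, so what happens when the amino group is replaced, for instance by a hydroxyl, is equally unknown.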